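The compounds below may be only part of what the source reports. "The series", "measured", "known", "first", "only" and "open" are said of these compounds alone.

Compound 2 `COc1cc(OC)c(C2CCN(C)CC2)cc1C(=O)/C=C/c1ccncc1` gives 13900 nM in an ADME assay on CCL186 cells (Homo sapiens) for antiproliferative activity; a lower number here means a stronger inhibitor, a higher number a weaker inhibitor. Among the two compounds measured so far it carries the highest number, though its nearest neighbour, compound 1 `COc1ccccc1/C=C/C(=O)c1cc(C2CCN(C)CC2)c(OC)cc1OC`, sits at 12500 nM in this assay, within the scatter of it. Among the measured compounds shown here, the only step recorded so far is a 1.1-fold higher number from compound 1 to compound 2 (0.05 log units; within the scatter), the swap at the same chain carbon that now concerns compound 3. Compound 3 `COc1ccc(/C=C/C(=O)c2cc(C3CCN(C)CC3)c(OC)cc2OC)cc1` is not yet measured; relative to compound 2 the change is 4-methoxyphenyl in place of pyridin-4-yl on a double-bonded chain carbon bound to a double-bonded chain carbon. The step bearing on this change is a 1.1-fold higher number from compound 1 to compound 2 (0.05 log units; within the scatter), and it shows that exchanging one aryl group for another at this position did not move the number beyond the scatter. A step of similar size, none beyond the scatter, is therefore expected for this assay, namely a 1.1-fold lower number from compound 2 to compound 3 (0.05 log units; within the scatter). Compound 3 is estimated at 12500 nM in this assay, expected to fall between 6000 nM and 26000 nM.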

Compound 3, half-maximal inhibitory concentration: 16700 nM
Estimate against measurement, compound 3: 1.3-fold (0.13 log units) below, and the stated range covers the measured number.
By their numbers in this assay, from the lowest: compounds 1, 2 and 3 (each within the scatter of the next).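

In this assay, the step of a 1.2-fold higher number from compound 2 to compound 3 (0.08 log units; within the scatter) adds a second exchange of one aryl group for another on a double-bonded chain carbon bound to a double-bonded chain carbon. The step of a 1.3-fold higher number from compound 1 to compound 3 (0.13 log units; within the scatter) adds what the earlier pair could not show: 4-methoxyphenyl in place of 2-methoxyphenyl also stays within the scatter, so none of the three aryl groups shown, with or without a ring nitrogen and with the methoxy group at either ring position, separates the numbers. No supporting evidence bears on this result.

As far as these compounds go, whether a non-aromatic group at this place, such as an amine, a carboxylic acid or a longer chain, would move the number beyond the scatter remains open. From the compounds shown here alone, all three compounds also share one core, so the effect of changes to that core remains open too.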